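Benzyloxy for chloro on the indole core: expectation

The source may hold more compounds than are shown below. What is called first, only, known or untested is meant among the compounds shown, and "the series" means these compounds.

Measured so far:
compound 1 `Brc1ccc2ccn(CCN3CCN4CCCCC4C3)c2c1` gives 70 nM
compound 2 `CN1CCCN(CCn2ccc3ccc(Br)cc32)CC1` gives 31 nM
compound 3 `CN1CCCN(CCn2ccc3ccc(Cl)cc32)CC1` gives 34 nM

In an assay on HEK293 cells for binding affinity to 5-hydroxytryptamine receptor 7 (Homo sapiens), read by radioligand binding (a lower number here means a stronger inhibitor, a higher number a weaker inhibitor), compound 3 stands second highest of the three numbers. Its nearest neighbour is compound 2, whose value sits within the scatter of compound 3; compound 1 stands furthest, beyond the scatter. Within the data shown here, the one step that compares two measured compounds differing in a single place is a 1.1-fold higher number from compound 2 to compound 3 (0.04 log units; within the scatter), a halogen swap on the aromatic carbon that changed nothing beyond the scatter.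

Compound 4 `CN1CCCN(CCn2ccc3ccc(OCc4ccccc4)cc32)CC1` is not yet measured. It differs from compound 3 as follows: benzyloxy in place of chloro on an aromatic carbon. This is a different kind of change from the halogen swap: the group that enters is far larger and carries a ring of its own. Among the measured compounds shown here, no measured pair bears directly on it; the step from compound 2 to compound 3 says only that exchanging one halogen for another at this position leaves this assay unchanged, and gives no guidance on a benzyloxy group. The expectation for compound 4 is therefore uncertain and the range kept wide. Compound 4 is estimated at 45 nM, within 10 nM to 200 nM, which means an expected step of a 1.3-fold higher number from compound 3 to compound 4 (0.12 log units; within the scatter).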

Compound 4, inhibition constant: 182 nM
Beside the measured number, compound 4's estimate is 4.0-fold (0.61 log units) below it; the range from low to high includes it.
By their numbers in this assay, from the lowest: compounds 2 and 3 (each within the scatter of the next); then compound 1; then compound 4.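

In this assay, among these compounds, this aromatic carbon responds to the group it carries, which the halogen pair could not show: a 1.1-fold higher number from compound 2 to compound 3 (0.04 log units; within the scatter) was the only step available, whereas benzyloxy gives a 5.4-fold higher number from compound 3 to compound 4 (0.73 log units; beyond the scatter) against chloro and a 5.9-fold higher number from compound 2 to compound 4 (0.77 log units; beyond the scatter) against bromo. The change is therefore not neutral at this position, although compound 4 still gives a measurable number at 182 nM and the larger group with its own aromatic ring does not remove binding in this assay altogether. Nothing available accounts for the size of this step, and a single benzyloxy compound cannot assign it to the oxygen, to the aromatic ring or to the group as a whole.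

Open, as far as these compounds go, is how a methoxy group or a phenyl ring on the same carbon would read in this assay, since either would separate the ether oxygen from the added ring. Also open, from the compounds shown here alone, is whether an amine or a carboxylic acid would be accepted here, and whether benzyloxy would give a similar step on the core of compound 1.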